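Shortening an ester chain and plasma half-life

The source may report more compounds than this note shows. Statements on the series, on what has been measured and on what is new or still open speak of the compounds shown alone.

Compound 1, `CC(C)OC(=O)c1cccc(NC(=O)c2cccc(-c3cc(C(=O)Nc4ccncc4F)ccc3CN)c2)c1`: 0.567 h
Compound 2, `COCCOC(=O)c1ccc(F)c(C(=O)Nc2cccc(-c3cc(C(=O)Nc4ccncc4F)ccc3CN)c2)c1`: a limit of the assay, < 0.0834 h

Of the compounds shown here, two have been tested in an ADME assay on a cell-free system (plasma, Homo sapiens) for metabolic stability, read by LC-MS; a lower number here means that the compound disappears faster, a higher number that the compound lasts longer. Compound 1 gives 0.567 h in this assay. For compound 2 this assay reports no number but a limit, < 0.0834 h, meaning the compound had disappeared before a half-life could be read. Compound 2 therefore stands at the limit of < 0.0834 h in this assay, at which 1 of the 2 values shown sits.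

Compound 3, `COC(=O)c1ccc(F)c(C(=O)Nc2cccc(-c3cc(C(=O)Nc4ccncc4F)ccc3CN)c2)c1`, has not yet been measured. It differs from compound 2 in one place only: hydrogen in place of methoxymethyl on a saturated chain carbon bound to an oxygen next to a carbonyl group. Both compounds carry an ester on the same shared core; compound 3 simply has the shorter methoxycarbonyl where compound 2 has the (2-methoxyethoxy)carbonyl. Within the data shown here, no pair of measured compounds differs in a single place, so no measured step exists to guide this one.

The step in this assay is expected to be small, a step that the limit leaves unreadable from compound 2 to compound 3, with no shift beyond the usual scatter. Compound 3 is thus expected to give 0.08 h, in a range from 0.03 h to 0.3 h, with a good chance that this assay again reports only a limit.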

Compound 3, half-life: 0.883 h
Compound 3: the middle estimate sits 11-fold (1.04 log units) below what was measured; measured number above the stated range.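

In this assay, shortening the (2-methoxyethoxy)carbonyl to the methoxycarbonyl gives an at least 10-fold higher number from compound 2 to compound 3 (1.02 log units; beyond the scatter). Among these compounds, this is the first single-place comparison, and it shows that this one change, on a saturated chain carbon bound to an oxygen next to a carbonyl group, can move the half-life well beyond the usual scatter, with everything else in the molecule held the same. The step can be read only as a minimum, because compound 2 gives a limit and not a number: the limit of < 0.0834 h in this assay, at which 1 of the 3 values shown sits.

One pair at one place cannot show how the half-life follows the chain, or whether removing the methoxymethyl would have the same effect on a different core. An ethyl ester would test whether the half-life changes gradually with chain length, while an amide or a carboxylic acid in place of the ester would test whether the same stretch of the molecule tolerates a different link to the shared core.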